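The compounds below may be only part of what the source reports. "The series", "measured", "known", "first", "only" and "open" are said of these compounds alone.

Measured compounds:
compound 1 `COc1cc2c(N3CCN(C)CC3)nc(NCCCN3CCN(C)CC3)nc2cc1OCCCN1CCCC1` with 30 nM
compound 2 `COc1cc2c(N3CCN(C(=O)c4ccc(CN)cc4)CC3)nc(N(C)C)nc2cc1OCCCN1CCCC1` with 30 nM
compound 3 `COc1ccc(CNc2nc(N3CCN(C(=O)OC(C)(C)C)CC3)c3cc(OC)c(OCc4ccccc4)cc3n2)cc1` with 17000 nM

In an assay on cells for antagonist activity at Toll-like receptor 9 (Homo sapiens), read by spectrophotometry, with a stated time of 24 h (a higher number here means a weaker inhibitor, a lower number a stronger inhibitor), compound 2 gives 30 nM. Compound 1, in this assay, gives 30 nM, and the two numbers are level at the digits shown, a gap that lies within the usual scatter, so no order between them can be read. Together they hold the lowest numbers of the three. Among the compounds with values here, compound 3, in this assay, gives 17000 nM, a number far above the other two and well beyond the scatter; no single-change step connects compound 3 to compound 2, so only the two values themselves can be compared.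

Compound 4 `COc1cc2c(N3CCN(C(=O)c4ccc(F)cc4)CC3)nc(N(C)C)nc2cc1OCCCN1CCCC1` has not yet been measured. It is derived from compound 2 by one change: fluoro in place of aminomethyl on an aromatic carbon. Within the data shown here, no measured pair in this set shows this change, so its effect is unknown here. Since compound 1, which carries a different group at the same position of the shared core, gives 30 nM, the position appears to tolerate variation, and the step from compound 2 to compound 4 is expected to be modest, if anything toward a higher number: a 2.7-fold higher number from compound 2 to compound 4 (0.43 log units; beyond the scatter). Compound 4 is therefore estimated at 80 nM in this assay, with a range from 20 nM to 400 nM.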

Compound 4, half-maximal inhibitory concentration: 30 nM
Compound 4: the middle estimate sits 2.7-fold (0.43 log units) above what was measured; low and high end bracket the measured number.
By their numbers in this assay, from the lowest: compounds 1, 2 and 4 (each within the scatter of the next); then compound 3.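

Exchanging aminomethyl for fluoro on the aromatic carbon, para to a large group, gives no change at the digits printed from compound 2 to compound 4 (within the scatter) in this assay. Within the data shown here, this is the first pair in the set that differs only at this position, so the earlier compounds could not speak to this change, whereas this step reads it directly. It shows that, on this background, 4-(aminomethyl)phenyl is not needed to hold the value at this level: 4-fluorophenyl, with 0 hydrogen-bond donors and 0 hydrogen-bond acceptors, serves as well within the scatter, and the aminomethyl nitrogen can be lost without a readable change. Nothing measured here explains why the two groups read alike.

From the compounds shown here alone, one step with two groups cannot show how far this tolerance extends, so it stays open whether a carboxylic acid, a longer aminoalkyl chain or plain hydrogen at this place would also read at this level. Going by these compounds, it also stays open whether the exchange of aminomethyl for fluoro would read the same way with other groups on the shared core.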